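This account rests on a few compounds, and the source may have more. Where it says the series, first, only, none or still open, it means among the compounds named here.

Measured in a functional assay on NCI-H522 cells (Homo sapiens) for cytotoxicity, with a stated time of 3 days; a lower number here means a stronger inhibitor, a higher number a weaker inhibitor:
- Compound 1 `C=Cc1nc2ccccc2s1`: > 40000 nM (a limit)
- Compound 2 `C=Cc1nc2ccccc2n1C`: 2340 nM
- Compound 3 `Ic1nc2ccccc2s1`: > 40000 nM (a limit)

For the measured compounds named here, compound 2 gives the only true number in this small set, 2340 nM. The other two results are the limit of > 40000 nM in this assay, at which 2 of the 3 values shown sit, and such a limit is not a number.

The next compound to consider is compound 4 `C#Cc1nc2ccccc2n1C`, which differs from compound 2 by one small swap: ethynyl in place of vinyl on an aromatic carbon.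

Going by the values given here, only one measured step touches a vinyl group on the core, and that is a step that the two limits leave unreadable from compound 1 to compound 3. It has a limit at both ends and a different incoming group, so it offers no size to carry over to this swap. With no measured guide, the sensible starting expectation in this assay is no clear shift in either direction, though the uncertainty is wide.

The estimated change is a 1.0-fold lower number from compound 2 to compound 4 (0.01 log units; within the scatter).

For compound 4 the expected value is 2300 nM, with an estimated range from 500 nM to 11000 nM.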

Compound 4, half-maximal inhibitory concentration: 8140 nM
Beside the measured number, compound 4's estimate is 3.5-fold (0.55 log units) below it; the measured number falls inside the stated range.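

In this assay the swap of vinyl for ethynyl, on the aromatic carbon between two ring nitrogen atoms, gives a 3.5-fold higher number from compound 2 to compound 4 (0.54 log units; beyond the scatter), the first readable size for any change at this position. With the core of compound 2 held fixed and the count of heavy atoms in the group unchanged, going from a double bond to a triple bond outside the ring is enough to give a weaker compound, yet compound 4 still gives a true number and not a limit. Nothing measured here explains why this shift occurs.

The compounds shown leave open how an amine, a carboxylic acid or a longer chain at this position would compare with vinyl and ethynyl. They also leave open whether ethynyl would act the same way on the core of compound 1, where the results shown are only limits.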